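Methyl on the aromatic carbon across two cores

A few compounds are considered here, and "the series" means these few. Any claim that something is new, unique, unknown or untested is made for them only; others in the source may bear on it.

Compound 1, `COC(=O)[C@@]1(C)CCC=C2[C@@H]1CC[C@@H](C)[C@]2(C)Cc1c[nH]c2ccccc12`, gives 8700 nM in a functional assay on WiDr cells (Homo sapiens) for inhibition, read by sulforhodamine B assay, with a stated time of 48 h; on this read-out lower numbers stand for stronger inhibition of growth and higher numbers for weaker inhibition of growth. Compound 2, `COC(=O)[C@@]1(C)CCC=C2[C@@H]1CC[C@@H](C)[C@]2(C)Cc1c[nH]c2c(C)cccc12`, differs from it by methyl in place of hydrogen on an aromatic carbon and gives 26000 nM in this assay; the step is a 3.0-fold higher number from compound 1 to compound 2 (0.48 log units; beyond the scatter). Compound 3, `COC(=O)[C@@]1(C)CC[C@@H]2C3=C1CC[C@@H](C)[C@]3(C)Cc1c2[nH]c2ccccc12`, carries a different core; the difference between the two cores is not broken down here. Compound 3 gives 4000 nM in this assay, the lowest of the three numbers.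

Compound 4, `COC(=O)[C@@]1(C)CC[C@@H]2C3=C1CC[C@@H](C)[C@]3(C)Cc1c2[nH]c2c(C)cccc12`, is the untested partner of compound 3, differing by methyl in place of hydrogen on an aromatic carbon. Among the compounds with values here, this is the same kind of change as the one from compound 1 to compound 2, with the place described differently: in compound 2 the six-membered aromatic ring is part of a fused or bridged system of two rings, in compound 4 part of a fused or bridged system of five rings. In both the carbon sits ortho to a fused ring and meta to a fused ring.

Within the data shown here, the only precedent for this change is the step from compound 1 to compound 2, which ran beyond the scatter toward weaker growth inhibition. On that single precedent compound 4 is expected to follow the same direction, with a step estimated at a 3.0-fold higher number from compound 3 to compound 4 (0.48 log units; beyond the scatter) in this assay. The estimate for compound 4 in this assay is 12000 nM, with a range from 5000 nM to 32000 nM expected to hold most repeat measurements.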

Compound 4, concentration for 50% growth inhibition: 22000 nM
Estimate against measurement, compound 4: 1.8-fold (0.26 log units) below; low and high end bracket the measured number.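

Methyl in place of hydrogen on an aromatic carbon again gives weaker growth inhibition in this assay, now on the core of compound 3, with a 5.5-fold higher number from compound 3 to compound 4 (0.74 log units; beyond the scatter). Set beside the earlier case, the two steps run in the same direction and cannot be told apart in size: the same change on two cores in this assay, a 3.0-fold higher number (0.48 log units; beyond the scatter) from compound 1 to compound 2 and a 5.5-fold higher number (0.74 log units; beyond the scatter) from compound 3 to compound 4, 1.8-fold (0.26 log units) apart, within the scatter of two such steps. The change therefore carried over between these two cores in this assay, but that reading rests on a single pair per core, says nothing about any other core and gives no explanation for the weaker inhibition.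

The compounds shown leave open whether a fluorine, a chlorine or a methoxy on the same aromatic carbon would behave as the methyl does, and whether methyl on other carbons of the six-membered aromatic ring would give a step of similar direction and size. Also open, going by these compounds, is how a carboxylic acid or an amide in place of the methyl ester would read on either core, and whether the difference between the two cores would hold with such groups.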